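The source may report more compounds than this note shows. Statements on the series, on what has been measured and on what is new or still open speak of the compounds shown alone.

The measured compounds are three:
compound 1, `OC[C@H]1O[C@@H](n2cnc3c(NCc4cccc(Br)c4)ncnc32)[C@H](O)[C@@H]1O`; in a functional assay on G-361 cells (Homo sapiens) for antiproliferative activity, with a stated time of 72 h (on this read-out higher numbers stand for weaker inhibition and lower numbers for stronger inhibition), compound 1 gives > 166000 nM, which is a limit of the assay and not a number.
compound 2, `OC[C@H]1O[C@@H](n2cnc3c(NCc4ccc(Cl)cc4Cl)ncnc32)[C@H](O)[C@@H]1O`; in this assay compound 2 gives 128000 nM.
compound 3, `COc1ccc(CNc2ncnc3c2ncn3[C@@H]2O[C@H](CO)[C@@H](O)[C@H]2O)c(OC)c1`; in this assay compound 3 gives "not determined" (no result reported), so no result is reported for it.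

Compound 3 thus stands nowhere on the numbers shown: it has no value of its own, and of the values that do exist one is the limit of > 166000 nM in this assay, at which 1 of the 3 values shown sits, so the measured ground lies at the weak end of the read-out. Compound 4 is `Cc1cccc(CNc2ncnc3c2ncn3[C@@H]2O[C@H](CO)[C@@H](O)[C@H]2O)c1O`, and it differs from compound 3 in one place: 2-hydroxy-3-methylphenyl in place of 2,4-dimethoxyphenyl on a saturated chain carbon bound to a nitrogen on an aromatic ring. Within the data shown here, the only measured step that touches the same place is an at least 1.2-fold lower number from compound 1 to compound 2 (0.11 log units; that floor lies within the scatter), an exchange of one aryl group for another on a saturated chain carbon bound to a nitrogen on an aromatic ring, and that step stayed within the scatter. On this basis a change of the aryl group at that place is expected to move this assay by little, if at all, beyond the scatter, and the number for compound 4 is expected to sit near the values of compound 1 and compound 2, with a fair chance that only a limit is returned. Compound 4 is therefore estimated at 150000 nM, within a range from 50000 nM to 400000 nM.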

Compound 4, half-maximal inhibitory concentration: > 166000 nM
Compound 4 was reported as a limit; the forecaster's own chance of this, stated with the estimate: 40%; at least 1.1-fold (0.04 log units) between middle value and limit.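

With compound 4, a phenyl group carrying a hydroxy group and a methyl group enters on a saturated chain carbon bound to a nitrogen on an aromatic ring, where the earlier values belonged to phenyl groups carrying only halogens, and in this assay the read-out stays at its weak end. Among these compounds, the one readable step is an at least 1.2-fold higher number from compound 2 to compound 4 (0.11 log units; that floor lies within the scatter), so this new kind of substituent, like the exchange of one halogen pattern for another, gives no move that can be claimed beyond the scatter, while the step from compound 1 to compound 4 cannot be read, as both values are limits. The values shown now gather at the weak end, and a second compound joins the first at the same limit: the limit of > 166000 nM in this assay, at which 2 of the 4 values shown sit.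

Compound 3 has no value to set against compound 4, so the change from 2,4-dimethoxyphenyl to 2-hydroxy-3-methylphenyl stays without a size. Also open, on these data alone, is whether a phenyl group bearing an amine or a carboxylic acid, or a longer chain in place of the saturated chain carbon, would bring the number down beyond the scatter.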